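Taking a methyl off a compound with no measured potency

The compounds below may be only part of what the source reports. "The series", "measured", "known", "first", "only" and "open" are said of these compounds alone.

Of the compounds shown here, two have so far been tested in a functional assay on CCRF-CEM cells (Homo sapiens) for cytotoxicity (on this read-out higher numbers stand for weaker inhibition and lower numbers for stronger inhibition), and neither yields a true number. Compound 1 (`O=c1ccn([C@@H]2C=C[C@H](CO)C2)c(=O)[nH]1`) gives > 100000 nM and this is a limit of the assay. Compound 2 (`Cc1cn(C2CCC(CO)C2)c(=O)[nH]c1=O`) gives > 100000 nM and this too is only a limit, which is all that can be said of where it stands. The next compound, compound 3 (`O=c1ccn(C2CCC(CO)C2)c(=O)[nH]1`), differs from compound 2 in one place, with hydrogen in place of methyl on an aromatic carbon. For the measured compounds named here, with the limit of > 100000 nM in this assay, at which 2 of the 2 values shown sit, as the only guide, compound 2 offers no reason to expect a change in either direction beyond the scatter. Going by the values given here, the estimated a number no higher from compound 2 to compound 3 (the limit leaves the size open) therefore amounts to no real step, and another limit is the likeliest report. Compound 3 is estimated at 100000 nM (expected range 30000 nM to 300000 nM).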

Compound 3, half-maximal inhibitory concentration: > 100000 nM
Compound 3: a limit, no number; the forecaster's own chance of this, stated with the estimate: 90%; the middle value sits exactly at the limit.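

Compound 2 and compound 3 each give only a limit and no true number, so no step can be read between them. The compounds shown leave open whether hydrogen in place of methyl on an aromatic carbon changes cytotoxic potency at all.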